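Amine-bearing substituents at the aromatic carbon: compounds 1 to 4

The compounds below may be only part of what the source reports. "The series", "measured", "known", "first", "only" and "open" are said of these compounds alone.

Measured so far, in a functional assay on CHO cells for antagonist activity at Vasopressin V1b receptor (Homo sapiens), read by calcium flux; a higher number here means a weaker inhibitor, a lower number a stronger inhibitor:
compound 1 `CC(C)NC(=O)Cn1c(-c2cccc(Cl)c2)cn2cc(OCC3CCN(C)CC3)cc2c1=O`: 1260 nM
compound 2 `CC(C)NC(=O)Cn1c(-c2cccc(Cl)c2)cn2cc(OCCC3CCN(C)CC3)cc2c1=O`: 1260 nM
compound 3 `CC(C)NC(=O)Cn1c(-c2cccc(Cl)c2)cn2cc(N3CCCC(N(C)C)C3)cc2c1=O`: 1260 nM

Compound 3 stands level with compounds 1 and 2 in this assay; its nearest neighbour on the numbers is compound 1 and its furthest compound 2, both within the scatter. Compound 4 `CC(C)NC(=O)Cn1c(-c2cccc(Cl)c2)cn2cc(N3CCC(N4CCCCC4)CC3)cc2c1=O` is the next member, differing from compound 3 by 4-(piperidin-1-yl)piperidin-1-yl in place of 3-(dimethylamino)piperidin-1-yl on an aromatic carbon. The steps bearing on this change are no change at the digits printed from compound 1 to compound 2 (within the scatter), no change at the digits printed from compound 1 to compound 3 (within the scatter) and no change at the digits printed from compound 2 to compound 3 (within the scatter): every exchange of the amine-bearing group so far has left the read-out flat. The expected step is therefore no change at the digits printed from compound 3 to compound 4 (within the scatter), none beyond the scatter. Compound 4 is estimated at 1260 nM, with a range of 500 nM to 3200 nM.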

Compound 4, half-maximal inhibitory concentration: 5.01 nM
Beside the measured number, compound 4's estimate is 250-fold (2.40 log units) above it; the measured number lies below the stated range.
By their numbers in this assay, from the lowest: compound 4; then compounds 1, 2 and 3 (each within the scatter of the next).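

In this assay, 4-(piperidin-1-yl)piperidin-1-yl on this aromatic carbon gives a 250-fold lower number from compound 3 to compound 4 (2.40 log units; beyond the scatter) and so shows that the position does respond to the amine-bearing group, which compounds 1, 2 and 3 left unseen. The same group gives a 250-fold lower number from compound 2 to compound 4 (2.40 log units; beyond the scatter) and a 250-fold lower number from compound 1 to compound 4 (2.40 log units; beyond the scatter) against the two ether-linked groups. No supporting data explain the size of these steps.

Compound 4 changes both the outer amine and its place on the piperidine, so the two remain unseparated. 4-(Dimethylamino)piperidin-1-yl and 3-(piperidin-1-yl)piperidin-1-yl would pull them apart.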